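Lengthening the chain toward the hydroxamic acid end

The source may report more compounds than this note shows. Statements on the series, on what has been measured and on what is new or still open speak of the compounds shown alone.

Measured compounds:
- compound 1, `C#CCN(C)Cc1cccc(NC(=O)CCC(=O)NO)c1`: > 10000 nM
- compound 2, `C#CCN(C)Cc1cccc(NC(=O)CCCC(=O)NO)c1`: > 10000 nM
- compound 3, `C#CCN(C)Cc1ccc(NC(=O)CCCCCCC(=O)NO)cc1`: 2280 nM

All three were tested in a functional assay on PC-3 cells (Homo sapiens) for inhibition, read by MTT assay, with a stated time of 48 h; a lower number here means a stronger inhibitor of growth, a higher number a weaker inhibitor of growth. Compound 1 reaches only the limit of the assay, > 10000 nM, and not a number. Compound 2 likewise sits at the limit, > 10000 nM. Among the measured compounds shown here, compound 3 is the one compound with a real number, 2280 nM. The step that the two limits leave unreadable from compound 1 to compound 2 therefore cannot be sized, because both ends rest on (the limit of > 10000 nM in this assay, at which 2 of the 3 values shown sit).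

The change from compound 1 to compound 2 is (hydroxycarbamoyl)methyl in place of hydroxycarbamoyl on a saturated chain carbon, two bonds along the chain from a carbonyl carbon. The change from compound 3 to the unmeasured compound 4, `C#CCN(C)Cc1ccc(NC(=O)CCCCCCCC(=O)NO)cc1`, is (hydroxycarbamoyl)methyl in place of hydroxycarbamoyl on a saturated chain carbon, six bonds along the chain from a carbonyl carbon. These are the same kind of change, not the same: in compound 1 the place is two bonds along the chain from a carbonyl carbon, in compound 3 it is six bonds along. The difference between the core of compound 1 and the core of compound 3 is not broken down here.

With only compound 3 giving a number, and the earlier step unreadable, the expectation for compound 4 rests on the value of compound 3, 2280 nM, and on the small size of the change. The step of a 1.3-fold higher number from compound 3 to compound 4 (0.12 log units; within the scatter) is expected to stay within the usual scatter. Compound 4 is estimated at 3000 nM, between 1000 nM and 9000 nM.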

Compound 4, concentration for 50% growth inhibition: 7160 nM
The estimate for compound 4 lay 2.4-fold (0.38 log units) below the measured number; measured number inside the range.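

In this assay, adding one chain carbon on the core of compound 3 gives a 3.1-fold higher number from compound 3 to compound 4 (0.50 log units; beyond the scatter), so here the longer chain goes with a modest but real weakening of growth inhibition. The same kind of change on the core of compound 1 cannot be read, because neither compound in that pair gives a number: the limit of > 10000 nM in this assay, at which 2 of the 4 values shown sit. This leaves one readable step, which shows what the change did on one core, at a place six bonds along the chain from a carbonyl carbon, but does not show whether a similar step would appear on the core of compound 1, where the place is two bonds along.

The compounds shown leave open whether a longer chain on the core of compound 4 would continue in the same direction, as a single step sets no trend with chain length. They also leave open how growth inhibition on either core would respond to a carboxylic acid in place of the hydroxycarbamoyl group at the end of the chain.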